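The compounds below may be only part of what the source reports. "The series", "measured", "known", "first", "only" and "open" are said of these compounds alone.

Measured in a functional assay on HL-60 cells (Homo sapiens) for inhibition, read by MTT assay, with a stated time of 72 h; on this read-out higher numbers stand for weaker inhibition and lower numbers for stronger inhibition:
compound 1 `Cc1nc(-c2ccccc2)c(C(=O)N2CCN(c3cccc(Cl)c3Cl)CC2)o1`: 133 nM
compound 2 `C=C(C)c1ccc(N2CCN(C(=O)c3oc(C)nc3-c3ccccc3)CC2)cc1`: "not active" (no number reported)
compound 3 `COc1cccc(N2CCN(C(=O)c3oc(C)nc3-c3ccc(F)cc3)CC2)c1`: 112 nM

Compound 3 stands level with compound 1: their two numbers lie within the scatter of each other, so this assay does not separate them. Compound 2 gives no number to set beside them. Among the measured compounds shown here, no two measured compounds differ in only one place, so the series offers no direct measure of any single change.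

Still unmeasured is compound 4 `COc1cccc(N2CCN(C(=O)c3oc(C)nc3-c3ccccc3)CC2)c1`. Its difference from compound 3 is hydrogen in place of fluoro on an aromatic carbon, which turns 4-fluorophenyl into phenyl. In this assay, a change this small is expected to stay within the scatter, with a slight lean towards a higher number. The estimated step is a 1.3-fold higher number from compound 3 to compound 4 (0.13 log units; within the scatter). The range is kept wide, as compound 2 shows "not active" (no number reported) within this series. For compound 4 the estimate is 150 nM, with an expected range of 50 nM to 450 nM.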

Compound 4, half-maximal inhibitory concentration: 34.8 nM
Compound 4: the middle estimate sits 4.3-fold (0.63 log units) above what was measured; the measured number lies below the stated range.
By their numbers in this assay, from the lowest: compound 4; then compounds 3 and 1 (each within the scatter of the next).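

In this assay, the fluoro on the aromatic carbon para to a large group is not a silent substituent: hydrogen in its place gives a 3.2-fold lower number from compound 3 to compound 4 (0.51 log units; beyond the scatter), the series' first direct measure of a change at this position. The group on the amine nitrogen in the ring also registers, with 3-methoxyphenyl in place of 2,3-dichlorophenyl giving a 3.8-fold lower number from compound 1 to compound 4 (0.58 log units; beyond the scatter). Nothing measured here accounts for either step.

On these data alone, the 4-fluorophenyl to phenyl change has been read only alongside 3-methoxyphenyl, so it remains open whether it would carry over alongside 2,3-dichlorophenyl. Among the compounds shown here, also open is how a methyl, hydroxyl or amine on that same aromatic carbon would compare, while compound 2 has no number, so no step to it can be read.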